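Cinnamamide aryl variation: toward the nitrophenyl analog

This account rests on a few compounds, and the source may have more. Where it says the series, first, only, none or still open, it means among the compounds named here.

Compound 3 `COc1ccc(C(=O)c2cc(OC)c(OC)c(OC)c2)cc1NC(=O)/C=C/c1cccc(OC(F)(F)F)c1` gives 9200 nM in a functional assay on ME-180 cells (Homo sapiens) for cytotoxicity, read by MTT assay, with a stated time of 72 h (a higher number here means a weaker inhibitor, a lower number a stronger inhibitor), the second highest of the three numbers measured. Compound 1 `COc1ccc(/C=C/C(=O)Nc2cc(C(=O)c3cc(OC)c(OC)c(OC)c3)ccc2OC)cc1` gives 11800 nM, and compound 2 `COc1ccc(C(=O)c2cc(OC)c(OC)c(OC)c2)cc1NC(=O)/C=C/c1ccc(F)cc1` gives 300 nM. The two steps reaching compound 3 are a 1.3-fold lower number from compound 1 to compound 3 (0.11 log units; within the scatter) and a 31-fold higher number from compound 2 to compound 3 (1.49 log units; beyond the scatter); the exchange of 4-methoxyphenyl for 4-fluorophenyl gives a 39-fold lower number from compound 1 to compound 2 (1.59 log units; beyond the scatter). Compound 4 `COc1ccc(C(=O)c2cc(OC)c(OC)c(OC)c2)cc1NC(=O)/C=C/c1ccc([N+](=O)[O-])cc1` differs from compound 3 by 4-nitrophenyl in place of 3-(trifluoromethoxy)phenyl on a double-bonded chain carbon bound to a double-bonded chain carbon. The three aryl groups already tried on this chain carbon span one large step and one within the scatter, so the direction of a fourth exchange is not fixed by the data. For compound 4 a lower number is expected, a 4.6-fold lower number from compound 3 to compound 4 (0.66 log units; beyond the scatter), of uncertain size. Compound 4 is estimated at 2000 nM, within 250 nM to 15000 nM.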

Compound 4, half-maximal inhibitory concentration: 9300 nM
For compound 4 the middle estimate is 4.7-fold (0.67 log units) below the measured one, within the range that was stated.
By their numbers in this assay, from the lowest: compound 2; then compounds 3, 4 and 1 (each within the scatter of the next).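

At this chain carbon, 4-nitrophenyl does not separate from 3-(trifluoromethoxy)phenyl in this assay (a 1.0-fold higher number from compound 3 to compound 4 (0.00 log units; within the scatter)) or from the 4-methoxyphenyl of compound 1 (a 1.3-fold lower number from compound 1 to compound 4 (0.10 log units; within the scatter)), while the gap to the 4-fluorophenyl of compound 2 remains large (a 31-fold higher number from compound 2 to compound 4 (1.49 log units; beyond the scatter)). Among these four aryl groups, compound 2 alone stands apart, with compound 1, compound 3 and compound 4 falling together. No supporting data explain this separation.

From the compounds shown here alone, whether a 4-chlorophenyl or 4-aminophenyl group at this carbon would fall with compound 2 or with the other three remains open.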